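Swapping the sulfonyl aryl on a triazole-bearing lactone

A few compounds are considered here, and "the series" means these few. Any claim that something is new, unique, unknown or untested is made for them only; others in the source may bear on it.

Measured compounds:
- Compound 1, `O=C1O[C@H]([C@@H](O)Cn2cc(-c3ccc(Br)cc3)nn2)C(OCc2ccccc2)=C1OCc1ccccc1`: 5070 nM
- Compound 2, `O=C1O[C@H]([C@@H](O)Cn2cc(CNS(=O)(=O)c3ccc(F)cc3)nn2)C(OCc2ccccc2)=C1OCc1ccccc1`: 18300 nM
- Compound 3, `O=C1O[C@H]([C@@H](O)Cn2ccnn2)C(OCc2ccccc2)=C1OCc1ccccc1`: a limit, > 100000 nM

In a functional assay on HepG2 cells (Homo sapiens) for antiproliferative activity, read by MTT assay, with a stated time of 72 h (on this read-out higher numbers stand for weaker inhibition and lower numbers for stronger inhibition), compound 1 gives 5070 nM. Compound 2 gives 18300 nM, the highest of the two plain numbers in this assay, a 3.6-fold higher number from compound 1 to compound 2 (0.56 log units; beyond the scatter). For compound 3 the assay gives only a limit, > 100000 nM (the limit of > 100000 nM in this assay, at which 1 of the 3 values shown sits). The two measured steps that move away from compound 2 are an at least 5.4-fold higher number from compound 2 to compound 3 (0.73 log units; beyond the scatter) and, seen from compound 1, an at least 19-fold higher number from compound 1 to compound 3 (1.29 log units; beyond the scatter); both alter the group on the triazole ring, not the aryl ring on the sulfonyl sulfur.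

Compound 4, `O=C1O[C@H]([C@@H](O)Cn2cc(CNS(=O)(=O)c3ccc(Cl)cc3F)nn2)C(OCc2ccccc2)=C1OCc1ccccc1`, differs from compound 2 in one place: 4-chloro-2-fluorophenyl in place of 4-fluorophenyl on a sulfonyl sulfur. For the measured compounds named here, no measured step changes this aryl ring, so there is no direct guide, and the expectation is a step no larger than the scatter, a 1.2-fold lower number from compound 2 to compound 4 (0.09 log units; within the scatter). Compound 4 is therefore estimated at 15000 nM, with a range from 6000 nM to 40000 nM.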

Compound 4, half-maximal inhibitory concentration: 25500 nM
Compound 4: the middle estimate sits 1.7-fold (0.23 log units) below what was measured, and the stated range covers the measured number.
By their numbers in this assay, from the lowest: compound 1; then compounds 2 and 4 (each within the scatter of the next). At a limit, above all of these: compound 3.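

For the compounds shown here, this is the first change to the aryl ring on the sulfonyl sulfur, and in this assay replacing 4-fluorophenyl with 4-chloro-2-fluorophenyl gives a 1.4-fold higher number from compound 2 to compound 4 (0.14 log units; within the scatter). The added chlorine and the altered fluorine pattern therefore leave the read-out without a distinguishable shift, unlike the change to the group on the triazole ring in a 3.6-fold higher number from compound 1 to compound 2 (0.56 log units; beyond the scatter). No available measurement bears on why this aryl change leaves the number within the scatter.

Both halogen differences arrive together, so the compounds shown leave open what 4-chlorophenyl or 2-fluorophenyl would each do alone. They also leave open whether this tolerance extends to very different groups on the sulfonyl sulfur, such as an aryl ring carrying an amine or a carboxylic acid, or a plain methyl.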